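Fluoro to Methoxy on the Shared Core: Free Fraction Outlook

The compounds below may be only part of what the source reports. "The series", "measured", "known", "first", "only" and "open" are said of these compounds alone.

Compound 1 `CC[C@H](c1ccc(C(=O)O)c(Oc2cccc(Cl)c2)c1F)N1CCC[C@H](n2cc(C)c(=O)[nH]c2=O)C1` has no result in an ADME assay on a cell-free system (plasma, Mus musculus) for protein binding, using equilibrium dialysis, with a stated time of 5 h, tested at 10 uM; on this read-out lower numbers stand for a smaller free fraction and higher numbers for a larger free fraction; its entry reads "not determined" (no result reported). Two close relatives were measured. Compound 2 `Cc1cn([C@H]2CCCN([C@H](CC(C)C)c3ccc(C(=O)O)c(Oc4cccc(Cl)c4)c3F)C2)c(=O)[nH]c1=O` reached only the limit of < 0.01 in this assay, which is a limit and not a number. Compound 3 `Cc1cn([C@H]2CCCN([C@@H](CC(C)C)c3ccc(C(=O)O)c(Oc4cccc(Cl)c4)c3F)C2)c(=O)[nH]c1=O` gives 0.005. The step that the limit leaves unreadable from compound 2 to compound 3 cannot be sized because of the limit of < 0.01 in this assay, at which 1 of the 3 values shown sits, although (the fact that compounds 2 and 3 differ only in the configuration as drawn). Compound 4 `CC[C@H](c1ccc(C(=O)O)c(Oc2cccc(Cl)c2)c1OC)N1CCC[C@H](n2cc(C)c(=O)[nH]c2=O)C1` differs from compound 1 by methoxy in place of fluoro on an aromatic carbon. Among the measured compounds shown here, no measured step matches this change, and compound 1 itself lacks a number, so no direction can be read; both measured relatives sit at small free fractions. Compound 4 is therefore expected to give about 0.008, within 0.002 to 0.03.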

Compound 4, unbound fraction: 0.006
Compound 4: middle estimate off by 1.3-fold (0.12 log units), on the high side; measured number inside the range.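

In this assay, among the compounds shown here, compound 4 gives no new step: compound 1, which differs from it in one place, has no number to compare. The compounds shown leave open how swapping fluoro for methoxy affects the unbound fraction.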